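Lactone series: aryl swap on the second benzylic arm

This account rests on a few compounds, and the source may have more. Where it says the series, first, only, none or still open, it means among the compounds named here.

Compound 2 `COc1cccc(C[C@H]2COC(=O)[C@@H]2Cc2ccc(Cl)c(Cl)c2)c1` gives 34000 nM in a functional assay on HL-60 cells (Homo sapiens) for cytotoxicity, read by WST assay, with a stated time of 48 h; a higher number here means that more compound is needed for the effect, a lower number that less compound is needed. Compound 1 `O=C1OC[C@H](Cc2ccccc2F)[C@H]1Cc1ccc(Cl)c(Cl)c1` gives 28000 nM and compound 3 `COc1cc(C[C@H]2COC(=O)[C@@H]2Cc2ccc(Cl)c(Cl)c2)ccc1O` gives 36000 nM in the same read-out, so compound 2 lies within the scatter of both neighbours and the three numbers cannot be told apart.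

The step to compound 4 `O=C1OC[C@H](Cc2ccc(Cl)c(Cl)c2)[C@H]1Cc1ccc(Cl)c(Cl)c1` changes one group: 3,4-dichlorophenyl in place of 3-methoxyphenyl on a saturated chain carbon bound to a saturated ring carbon. The same chain carbon has been varied once before, and that step, a 1.2-fold higher number from compound 1 to compound 2 (0.08 log units; within the scatter), stayed within the scatter. The change to the aromatic substituent in a 1.1-fold higher number from compound 2 to compound 3 (0.02 log units; within the scatter) likewise stayed within the scatter. Going by the values given here, both measured steps therefore point to this chain carbon as a place where the identity of the aryl group has so far not moved the cytotoxicity number beyond the scatter, with the caveat that only three compounds are known and a dichlorinated ring has not yet been tried there.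

For compound 4 the step of a 1.1-fold lower number from compound 2 to compound 4 (0.05 log units; within the scatter) is accordingly expected to fall within the scatter, with no preferred direction. The estimate for compound 4 is 30000 nM, with a range from 12000 nM to 75000 nM.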

Compound 4, half-maximal effective concentration: 20000 nM
For compound 4 the middle estimate is 1.5-fold (0.18 log units) above the measured one; the range from low to high includes it.
By their numbers in this assay, from the lowest: compounds 4, 1, 2 and 3 (each within the scatter of the next).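

Placing 3,4-dichlorophenyl on a saturated chain carbon bound to a saturated ring carbon gives compound 4 the same group on both benzylic arms, yet the number in this assay stays within the scatter of the compounds it replaces (a 1.7-fold lower number from compound 2 to compound 4 (0.23 log units; within the scatter); a 1.4-fold lower number from compound 1 to compound 4 (0.15 log units; within the scatter)). The earlier steps shown here at this position exchanged only singly substituted rings, whereas this change brings in a ring with two chlorines and removes the hydrogen-bond acceptor of the 3-methoxyphenyl group, and still no step at this carbon goes beyond the scatter. No data are at hand that bear on why these numbers stay together.

Every compound shown carries a substituted phenyl at this position, so the effect of an amine, a carboxylic acid or a longer chain on this chain carbon in this assay remains open. All four compounds also share the 3,4-dichlorophenyl on the other arm and the same core, which leaves open whether a change at either of those places would move the number beyond the scatter.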